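The compounds below may be only part of what the source reports. "The series", "measured", "known", "first", "only" and "open" are said of these compounds alone.

Compound 1 `CS(=O)(=O)c1ccc(-c2oc3ccccc3c(=O)c2-c2ccccc2)cc1` was examined in an assay on isolated protein for inhibition of prostaglandin G/H synthase 1 (Mus musculus), tested at 10 ug/mL; a higher number here means more inhibition at the concentration tested (going by the name of the read-out), a lower number less inhibition. In this assay compound 1 gives only a limit of the assay, < 5%. Two related compounds are also known: compound 2 `CS(=O)(=O)c1ccc(-c2oc3ccccc3c(=S)c2-c2ccc(Cl)c(Cl)c2)cc1` and compound 3 `CS(=O)(=O)c1ccc(-c2oc3ccccc3c(=S)c2-c2ccccc2)cc1`. In this assay compound 2 gives a limit, < 5%. In this assay compound 3 also gives a limit, < 5%. The step that the two limits leave unreadable from compound 2 to compound 3 therefore cannot be read. Compound 4 `CS(=O)(=O)c1ccc(-c2oc3ccccc3c(=O)c2-c2ccc(Cl)cc2)cc1` differs from compound 1 by chloro in place of hydrogen on an aromatic carbon. Going by the values given here, no measured step shows what a chloro does to this read-out, and every value so far shares (the limit of < 5% in this assay, at which 3 of the 3 values shown sit). Compound 4 is therefore expected to stay near that limit, with a step that the limit leaves unreadable from compound 1 to compound 4 within the scatter. The estimate for compound 4 is 3%, between 0% and 12%.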

Compound 4, a percentage reported as inhibition, at one concentration (the size of the read-out at that concentration, not a potency): < 5%
Compound 4 ended at the assay's limit; the forecaster's own chance of this, stated with the estimate: 80%; the middle value does not contradict the limit.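

The step from compound 1 to compound 4 cannot be read, since neither compound gives a number, only a limit: the limit of < 5% in this assay, at which 4 of the 4 values shown sit. The compounds shown leave open whether any change to this shared core gives a measurable inhibition in this assay.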